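A few compounds are considered here, and "the series" means these few. Any claim that something is new, unique, unknown or untested is made for them only; others in the source may bear on it.

Measured so far:
Compound 1, `Cc1cc(C)nc(Sc2ccnc(Nc3ccc(C#N)cc3)n2)n1`: 224000 nM
Compound 2, `CN(C)c1ccnc(Nc2ccc(C#N)cc2)n1`: 34000 nM
Compound 3, `Cc1cccc(COc2ccnc(Nc3ccc(C#N)cc3)n2)c1`: 30000 nM

Of the compounds shown here, three built on a shared core have been tested in an ADME assay on MT4 cells (Homo sapiens) for cytotoxicity, read by MTT assay, with a stated time of 5 days; a lower number here means that less compound is tolerated, a higher number that more compound is tolerated. Compound 1 `Cc1cc(C)nc(Sc2ccnc(Nc3ccc(C#N)cc3)n2)n1` gives 224000 nM in this assay. Compound 2 `CN(C)c1ccnc(Nc2ccc(C#N)cc2)n1` gives 34000 nM. Compound 3 `Cc1cccc(COc2ccnc(Nc3ccc(C#N)cc3)n2)c1` gives 30000 nM. Compound 3 and compound 2 cannot be separated, their two numbers lying within the scatter of each other, whereas compound 1 is tolerated at a higher concentration than compound 3 by a margin that lies beyond the scatter. Among the measured compounds shown here, no step between two compounds differing in one place is available, so nothing about how single changes move this read-out can be drawn from these three.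

The next compound, compound 4 `N#Cc1ccc(Nc2nccc(OCc3ccccc3)n2)cc1`, differs from compound 3 by hydrogen in place of methyl on an aromatic carbon. This is a small change, the loss of a single carbon from a group that is already far from the core. For the measured compounds named here, since nothing among the measured compounds speaks for a large effect of such a change, compound 4 is expected to show no step beyond the scatter, with a 1.2-fold higher number from compound 3 to compound 4 (0.07 log units; within the scatter) as the estimated move. Compound 4 is therefore estimated at 35000 nM in this assay, within a range of 15000 nM to 80000 nM.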

Compound 4, half-maximal cytotoxic concentration: 13000 nM
The estimate for compound 4 lay 2.7-fold (0.43 log units) above the measured number; the whole stated range lies above it.
By their numbers in this assay, from the lowest: compound 4; then compounds 3 and 2 (each within the scatter of the next); then compound 1.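

In this assay, among the compounds shown here, going from the 3-methylbenzyl group to the benzyl group gives a 2.3-fold lower number from compound 3 to compound 4 (0.36 log units; beyond the scatter), the first step in this set that isolates a change in one place. The step is modest but beyond the scatter, so this aromatic carbon is not a silent position for the read-out: with hydrogen in place of methyl, less compound is tolerated, even though only one carbon has left the structure. No measurement shown accounts for this shift, so the step stands as an observation from a single pair, without an explanation.

The compounds shown leave open whether the direction of this step is tied to methyl itself or would also appear with a larger or different group at the same place, such as an ethyl, a methoxy or a chlorine. They also leave open whether a methyl on another carbon of the same ring would give a similar step, and whether the same exchange would move the number by a similar amount on a compound carrying a different link to the shared core, such as a sulfur or an amine.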